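Swapping a chloroaryl for a fluorobenzoyl on the hydrazide

A few compounds are considered here, and "the series" means these few. Any claim that something is new, unique, unknown or untested is made for them only; others in the source may bear on it.

Three compounds sharing one sulfonamide core were tested in a functional assay on SGC-7901 cells (Homo sapiens) for antiproliferative activity, read by MTT assay, with a stated time of 24 h; on this read-out higher numbers stand for weaker inhibition and lower numbers for stronger inhibition. Compound 1 `Cc1ccccc1NNC(=O)c1ccc(NS(=O)(=O)c2cnc(O)nc2O)cc1` reached only a limit, > 20000 nM, and reports no number. Compound 3 `Cc1ccccc1C(=O)NNC(=O)c1cccc(NS(=O)(=O)c2cnc(O)nc2O)c1` likewise stopped at a limit, > 20000 nM. Both rest at the limit of > 20000 nM in this assay, at which 2 of the 3 values shown sit. Going by the values given here, compound 2 `O=C(NNc1cccc(Cl)c1)c1ccccc1NS(=O)(=O)c1cnc(O)nc1O` is the only member with a measured value, 10800 nM, so it alone anchors the series. Compound 4 `O=C(NNC(=O)c1ccccc1NS(=O)(=O)c1cnc(O)nc1O)c1ccc(F)cc1` is its untested relative, differing by (4-fluorophenyl)carbonyl in place of 3-chlorophenyl on an amine nitrogen. Among the compounds with values here, no measured pair shows how such a change plays out here, so the step is expected to be small, most likely toward weaker inhibition, with a fair chance that compound 4 also ends at a limit: a 1.7-fold higher number from compound 2 to compound 4 (0.22 log units; within the scatter). Compound 4 is therefore estimated at 18000 nM, within 8000 nM to 40000 nM.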

Compound 4, half-maximal inhibitory concentration: > 20000 nM
Compound 4 ended at the assay's limit; the forecaster's own chance of this, stated with the estimate: 50%; middle value at least 1.1-fold (0.04 log units) from the limit.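

In this assay, going by these compounds alone, placing (4-fluorophenyl)carbonyl instead of 3-chlorophenyl on this amine nitrogen gives an at least 1.8-fold higher number from compound 2 to compound 4 (0.26 log units; that floor lies within the scatter) as the only measured step at this place. As far as these compounds go, that figure is just a floor and lies within the scatter, so the true size of the change stays unknown. Compound 4 gives a limit rather than a number: the limit of > 20000 nM in this assay, at which 3 of the 4 values shown sit.

Within the data shown here, compound 2 therefore remains the only compound here with a number. From the compounds shown here alone, it remains open whether the added carbonyl or the change from chlorine to fluorine matters more, and how a plain phenyl or a methyl would behave on this nitrogen.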